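The source may hold more compounds than are shown below. What is called first, only, known or untested is meant among the compounds shown, and "the series" means these compounds.

Compound 1 `C#CCNC1CCc2c(SCCc3ccc(C(F)(F)F)cc3)cccc21` — 8780 nM
Compound 2 `C#CCNC1CCc2c(SCCc3cccc(F)c3)cccc21` — 7810 nM

These two values come from an ADME assay on isolated protein for inhibition of Amine oxidase [flavin-containing] B (Homo sapiens); on this read-out lower numbers stand for stronger inhibition and higher numbers for weaker inhibition. Compound 2 stands beside compound 1 rather than apart from it: the two numbers lie within the scatter of each other, so nothing can be said about a change between them. Compound 3 `C#CCNC1CCc2c(SCCc3ccc(C)cc3)cccc21` differs from compound 2 by 4-methylphenyl in place of 3-fluorophenyl on a saturated chain carbon, two bonds along the chain from a sulfur. Going by the values given here, no step between measured compounds exists to guide this change, and the two known numbers sit close together, so a step of a 1.0-fold lower number from compound 2 to compound 3 (0.02 log units; within the scatter) is expected, none beyond the scatter. For compound 3 the estimate in this assay is 7500 nM, expected to fall between 3000 nM and 20000 nM.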

Compound 3, half-maximal inhibitory concentration: 4520 nM
Beside the measured number, compound 3's estimate is 1.7-fold (0.22 log units) above it; the range from low to high includes it.
By their numbers in this assay, from the lowest: compounds 3, 2 and 1 (each within the scatter of the next).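

In this assay 4-methylphenyl in place of 3-fluorophenyl on a saturated chain carbon, two bonds along the chain from a sulfur, gives a 1.7-fold lower number from compound 2 to compound 3 (0.24 log units; within the scatter) and methyl in place of trifluoromethyl on an aromatic carbon gives a 1.9-fold lower number from compound 1 to compound 3 (0.29 log units; within the scatter) with both steps inside the scatter. This position thus carries all three aryl groups shown without a readable difference between them. No measurement at hand bears on this result. The compounds shown leave open whether an amine, a carboxylic acid or a longer chain here would give a step beyond the scatter.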